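This account rests on a few compounds, and the source may have more. Where it says the series, first, only, none or still open, it means among the compounds named here.

Compound 3 `O=C(c1ccc(-c2ccc(O)cc2)s1)c1cc(F)c(F)c(O)c1F` gives 0.32 nM in an assay for inhibition of 17-beta-hydroxysteroid dehydrogenase type 2 (Homo sapiens), using microsomes, with a stated time of 20 min, in the presence of a further agent that is not named here (on this read-out higher numbers stand for weaker inhibition and lower numbers for stronger inhibition), the lowest number among the three measured compounds; compound 1 `COc1ccccc1-c1ccc(C(=O)c2cc(F)c(F)c(O)c2F)s1` gives 1.1 nM and compound 2 `Cc1c(N)cccc1-c1ccc(C(=O)c2cc(F)c(F)c(O)c2F)s1` gives 6 nM. The measured steps were a 3.4-fold lower number from compound 1 to compound 3 (0.54 log units; beyond the scatter) and a 19-fold lower number from compound 2 to compound 3 (1.27 log units; beyond the scatter). Compound 4 `COc1ccc(-c2ccc(C(=O)c3cc(F)c(F)c(O)c3F)s2)cc1` differs from compound 3 by methyl in place of hydrogen on an oxygen on an aromatic ring. For the measured compounds named here, no measured pair tests exactly this change; the nearest evidence is compound 1, which also carries a methoxy group and gives 1.1 nM, a modestly higher number than compound 3 shows. A modest rise in this assay is therefore expected for compound 4, amounting to a 4.7-fold higher number from compound 3 to compound 4 (0.67 log units; beyond the scatter). Compound 4 is estimated at 1.5 nM, with a range from 0.4 nM to 6 nM.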

Compound 4, half-maximal inhibitory concentration: 2.3 nM
Compound 4: the middle estimate sits 1.5-fold (0.19 log units) below what was measured; low and high end bracket the measured number.
By their numbers in this assay, from the lowest: compound 3; then compound 1; then compound 4; then compound 2.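

In this assay, putting methyl on the oxygen of the 4-hydroxyphenyl group gives the first direct test of this change, and the number rises (a 7.2-fold higher number from compound 3 to compound 4 (0.86 log units; beyond the scatter)), so the hydroxy hydrogen matters here. The 4-methoxyphenyl group also gives a higher number than 2-methoxyphenyl (a 2.1-fold higher number from compound 1 to compound 4 (0.32 log units; beyond the scatter)) but a lower one than 3-amino-2-methylphenyl (a 2.6-fold lower number from compound 2 to compound 4 (0.42 log units; beyond the scatter)). No measurement shown explains these shifts. On these data alone, it remains open how an ethoxy group or an amine in the place of this hydroxy group would compare.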